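The compounds below may be only part of what the source reports. "The series", "measured", "known", "first", "only" and "open" are said of these compounds alone.

Compounds with numbers in hand:

compound 1, `CCN(CC)S(=O)(=O)c1ccc(S(=O)(=O)N2CCC[C@@H](C(=O)N[C@@H]3CCN(C(=O)OC(C)(C)C)C3)C2)cc1`, 400 nM
compound 2, `CCCN(CCC)S(=O)(=O)c1ccc(S(=O)(=O)N2CCC[C@@H](C(=O)OCC)C2)cc1`, 2500 nM
compound 3, `CCN1CC(NC(=O)[C@@H]2CCCN(S(=O)(=O)c3ccc(S(=O)(=O)N(CC)CC)cc3)C2)C1`, limit > 30000 nM

In a functional assay on BXPC-3 cells (Homo sapiens) for inhibition, read by MTT assay, with a stated time of 7 days (on this read-out lower numbers stand for stronger inhibition and higher numbers for weaker inhibition), compound 2 gives 2500 nM, the higher of the two numbers recorded; compound 1, with the same core and a different ester-side group, gives 400 nM. For compound 3 the value > 30000 nM is a limit of the assay and not a number, and this is the point (the limit of > 30000 nM in this assay, at which 1 of the 3 values shown sits).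

Compound 4, `CCOC(=O)[C@@H]1CCCN(S(=O)(=O)c2ccc(S(=O)(=O)N3CCCCC3)cc2)C1`, differs from compound 2 in one place: piperidin-1-yl in place of dipropylamino on a sulfonyl sulfur. For the measured compounds named here, the only measured step with a single change, an at least 75-fold higher number from compound 1 to compound 3 (1.87 log units; beyond the scatter), concerns the amide-type nitrogen and not the group on the sulfonyl sulfur, so no measured step bears directly on the change from compound 2 to compound 4. The two groups that swap are of similar size and each carries one nitrogen. Going by the values given here, with no step of this kind measured, the expectation for compound 4 is a number close to that of compound 2, within the scatter, as a 1.1-fold lower number from compound 2 to compound 4 (0.06 log units; within the scatter). Compound 4 is therefore estimated at 2200 nM, with a range from 600 nM to 8000 nM.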

Compound 4, half-maximal inhibitory concentration: 3300 nM
Compound 4: the middle estimate sits 1.5-fold (0.18 log units) below what was measured; measured number inside the range.
By their numbers in this assay, from the lowest: compound 1; then compounds 2 and 4 (each within the scatter of the next). At a limit, above all of these: compound 3.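

In this assay, for the compounds shown here, this pair gives the first reading of a change on the sulfonyl sulfur with the rest of the molecule held constant: a 1.3-fold higher number from compound 2 to compound 4 (0.12 log units; within the scatter). Replacing the open-chain dipropylamino with the six-membered ring of piperidin-1-yl therefore leaves compound 2 and compound 4 indistinguishable on this read-out, so in this pair the assay does not separate the two groups at this place. Nothing among the measurements shown accounts for this result, and the limit recorded for compound 3 concerns a change on the amide-type nitrogen.

On these data alone, it remains open whether a ring bearing a second hetero atom, such as morpholin-4-yl, or a shorter group, such as dimethylamino, would also match compound 2 at this place. As far as these compounds go, it is equally open whether piperidin-1-yl would behave in the same way alongside the amide side chain of compound 1, which gives 400 nM with diethylamino on the sulfonyl sulfur.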